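This account rests on a few compounds, and the source may have more. Where it says the series, first, only, none or still open, it means among the compounds named here.

In a functional assay on A-431 cells (Homo sapiens) for cytotoxicity (on this read-out lower numbers stand for an effect already at smaller amounts and higher numbers for an effect only at larger amounts of compound), three compounds have been measured so far:

compound 1, `COC1=C(C)C(=O)/C(=C(O)/C=C/c2ccccc2OC)C(=O)C1(C)C`: 6.6 ug/mL
compound 2, `COC1=C(C)C(=O)/C(=C(O)/C=C/c2ccc(O)cc2)C(=O)C1(C)C`: 14.9 ug/mL
compound 3, `CCc1ccc(/C=C/C(O)=C2/C(=O)C(C)=C(OC)C(C)(C)C2=O)cc1`: 12 ug/mL

Compound 1 stands lowest of these three numbers. Its nearest neighbour is compound 3, reached by a 1.8-fold higher number from compound 1 to compound 3 (0.26 log units; within the scatter); its furthest is compound 2, reached by a 2.3-fold higher number from compound 1 to compound 2 (0.35 log units; beyond the scatter). Compound 4, `COC1=C(C)C(=O)/C(=C(O)/C=C/c2nccs2)C(=O)C1(C)C`, has not yet been measured. It differs from compound 1 in one place: 1,3-thiazol-2-yl in place of 2-methoxyphenyl on a double-bonded chain carbon bound to a double-bonded chain carbon. Both measured steps from compound 1 swap the same 2-methoxyphenyl for another aromatic ring at the same place, and both gave higher numbers, one within the scatter, one modestly beyond it. A similar modest rise is therefore expected for the thiazolyl ring, with wide uncertainty since no heteroaromatic ring has been measured here. Compound 4 is expected to give 12 ug/mL, with a range from 5 ug/mL to 30 ug/mL. The expected step is a 1.8-fold higher number from compound 1 to compound 4 (0.26 log units; within the scatter).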

Compound 4, concentration for half-maximal effect: 6 ug/mL
Compound 4: middle estimate off by 2.0-fold (0.30 log units), on the high side; the measured number falls inside the stated range.
By their numbers in this assay, from the lowest: compounds 4, 1, 3 and 2 (each within the scatter of the next, the first and the last beyond it).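

In this assay the place on a double-bonded chain carbon bound to a double-bonded chain carbon tolerates a five-membered aromatic ring with 2 hetero atoms: 1,3-thiazol-2-yl stays within the scatter of both 2-methoxyphenyl (a 1.1-fold lower number from compound 1 to compound 4 (0.04 log units; within the scatter)) and 4-ethylphenyl (a 2.0-fold lower number from compound 3 to compound 4 (0.30 log units; within the scatter)). Within the data shown here, only the step from 4-hydroxyphenyl lies beyond the scatter (a 2.5-fold lower number from compound 2 to compound 4 (0.40 log units; beyond the scatter)). Nothing at hand explains this result. The compounds shown leave open whether a pyridyl or furyl ring at this place would give a similar number. They also leave open what a saturated ring or plain alkyl chain would give there.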